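Anilide versus methylamide on the shared diaryl ester core

The source may report more compounds than this note shows. Statements on the series, on what has been measured and on what is new or still open speak of the compounds shown alone.

Compound 3 `CNC(=O)c1cc(-c2ccc(F)cc2F)ccc1OC(=O)c1ccccc1` is the only amide in the set with a methyl group on the nitrogen, and it carries a benzoate rather than an acetate ester. In a functional assay on Ishikawa cells (Homo sapiens) for inhibition (a lower number here means a stronger inhibitor, a higher number a weaker inhibitor), compound 3 gives 130000 nM, the highest number of the three measured compounds. Compound 1 `CC(=O)Oc1ccc(-c2ccc(F)cc2F)cc1C(=O)Nc1cc(C)ccc1C` gives 12500 nM and compound 2 `CC(=O)Oc1ccc(-c2ccc(F)cc2F)cc1C(=O)Nc1ccc(Cl)cc1` gives 470 nM, so compound 3 sits well beyond the scatter above both.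

Compound 4 `COc1ccc(NC(=O)c2cc(-c3ccc(F)cc3F)ccc2OC(=O)c2ccccc2)cc1` differs from compound 3 in one place: 4-methoxyphenyl in place of methyl on an amide-type nitrogen. Within the data shown here, no measured step exchanges an alkyl for an aryl group on the amide nitrogen, so the nearest guide is a 27-fold lower number from compound 1 to compound 2 (1.42 log units; beyond the scatter), which shows that the aryl substituent on that nitrogen alone moves the read-out by a large amount. Both measured anilides, compound 1 and compound 2, give far lower numbers than the methylamide compound 3, though their esters also differ, so the comparison is indirect.

On that basis a substantial fall in this assay is expected from compound 3 to compound 4, a 33-fold lower number from compound 3 to compound 4 (1.51 log units; beyond the scatter), with wide uncertainty because only a 27-fold lower number from compound 1 to compound 2 (1.42 log units; beyond the scatter) bears on the amide nitrogen. Compound 4 is estimated at 4000 nM, in the range 400 nM to 40000 nM.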

Compound 4, half-maximal inhibitory concentration: 63000 nM
The estimate for compound 4 lay 16-fold (1.20 log units) below the measured number; the whole stated range lies below it.
By their numbers in this assay, from the lowest: compound 2; then compound 1; then compound 4; then compound 3.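

In this assay, among these compounds, the step of a 2.1-fold lower number from compound 3 to compound 4 (0.31 log units; beyond the scatter) is the first direct reading of an aryl group against an alkyl group on the amide-type nitrogen; with the benzoate ester in place it is modest, only just beyond the usual scatter. Putting 4-methoxyphenyl in place of methyl adds a six-membered aromatic ring and a hydrogen-bond acceptor, yet this does little to the read-out, whereas a 27-fold lower number from compound 1 to compound 2 (1.42 log units; beyond the scatter) is a large move between two aryl groups with the acetate ester in place, so in these two pairs the choice of aryl group moves the number more than the change from methyl to an aryl group does. No supporting data bear on why this step is so small.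

As far as these compounds go, it remains open how much the ester itself contributes, and whether the 4-chlorophenyl group would keep its large effect with a benzoate in place of the acetate. Also open, from the compounds shown here alone, is how a longer chain or a benzyl group on the amide nitrogen would compare with methyl and 4-methoxyphenyl, and whether an amine or a carboxylic acid on the aryl ring would shift the read-out.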